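The compounds below may be only part of what the source reports. "The series", "measured", "known", "first", "only" and "open" are said of these compounds alone.

Compound 1 `COc1cc(-c2nn(-c3cccc(NC(=O)c4cccc(C(F)(F)F)c4)c3)cc2-c2ccncc2)ccc1Cl` carries an amide whose aryl bears a trifluoromethyl group. In a functional assay on CAKI-1 cells (Homo sapiens) for inhibition, read by sulforhodamine B assay, with a stated time of 48 h (on this read-out higher numbers stand for weaker inhibition of growth and lower numbers for stronger inhibition of growth), compound 1 gives 2010 nM, the highest of the three numbers recorded here. Compound 2 `O=C(Nc1cccc(-n2cc(-c3ccncc3)c(-c3ccc(Cl)c(O)c3)n2)c1)Nc1cc(C(F)(F)F)cc(C(F)(F)F)c1` gives 1010 nM, a value that lies within the scatter of compound 1, so the two cannot be ranked. Among the compounds with values here, compound 3 `COc1cc(-c2nn(-c3cccc(NC(=O)Nc4ccc(Cl)c(C(F)(F)F)c4)c3)cc2-c2ccncc2)ccc1Cl` gives 992 nM; the single step that can be drawn, a 2.0-fold lower number from compound 1 to compound 3 (0.31 log units; beyond the scatter), swaps the amide aryl for a urea-linked aryl and is modest in size.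

Compound 4 `COc1cc(-c2nn(-c3cccc(NC(=O)c4ccccc4)c3)cc2-c2ccncc2)ccc1Cl` differs from compound 1 by hydrogen in place of trifluoromethyl on an aromatic carbon. Within the data shown here, no measured step touches this change: the one step recorded replaces the whole aryl group and adds an amino linker at the same time, so it offers only a loose guide. It shows that a modest change at this end of the molecule moves the number by a modest amount, and nothing more. Compound 1 would therefore be expected to keep roughly its value, with any step a 1.5-fold higher number from compound 1 to compound 4 (0.17 log units; within the scatter) not clearly beyond the scatter. For compound 4 the estimate is 3000 nM, expected to fall between 1000 nM and 9000 nM.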

Compound 4, concentration for 50% growth inhibition: 1160 nM
The estimate for compound 4 lay 2.6-fold (0.41 log units) above the measured number, and the stated range covers the measured number.
By their numbers in this assay, from the lowest: compounds 3, 2, 4 and 1 (each within the scatter of the next, the first and the last beyond it).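

With hydrogen in place of trifluoromethyl on this aromatic carbon, the step is a 1.7-fold lower number from compound 1 to compound 4 (0.24 log units; within the scatter), so in this assay the trifluoromethyl group of compound 1 is not shown to be needed for the number it gives, and the plain benzoyl amide of compound 4 cannot be separated from it. Within the data shown here, this is the first reading of the trifluoromethyl group alone, since the earlier step replaced the whole aryl group and added an amino linker at the same time. The second new step, a 1.2-fold higher number from compound 3 to compound 4 (0.07 log units; within the scatter), also lies within the scatter, so the urea with its substituted aryl in compound 3 holds no demonstrated edge over the unsubstituted benzoyl amide, even though it stood apart from compound 1.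

On these data alone, it remains open whether a nitrile, an amine or a carboxylic acid on this aromatic carbon would move the number beyond the scatter of compound 4, or whether this carbon tolerates such groups as readily as it does trifluoromethyl and hydrogen. Nothing given here accounts for why these compounds read so closely in this cell assay.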